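A few compounds are considered here, and "the series" means these few. Any claim that something is new, unique, unknown or untested is made for them only; others in the source may bear on it.

Measured so far in a functional assay on CHO cells for antagonist activity at Orexin/Hypocretin receptor type 1 (Homo sapiens), read by FLIPR; a higher number here means a weaker inhibitor, a lower number a stronger inhibitor:
compound 1 `COc1cccc(C(=O)N2CCCCC2CCOc2ccc(Cl)c(Cl)c2)c1` gives 126 nM
compound 2 `O=C(c1ccccc1-c1ccccc1)N1CCCCC1CCOc1ccc(F)cc1` gives 5.01 nM
compound 3 `O=C(c1ccccc1-c1ccccc1)N1CCCC[C@H]1CCOc1ccc(F)cc1F` gives 0.159 nM

Compound 3 gives the lowest number of the three; the gap to compound 2 is the narrowest and still beyond the scatter, and the gap to compound 1 is wider again. Compound 4 `O=C(CC[C@@H]1CCCCN1C(=O)c1ccccc1-c1ccccc1)c1ccccc1` is not yet measured. It differs from compound 3 in one place: benzoyl in place of 2,4-difluorophenoxy on a saturated chain carbon, two bonds along the chain from a saturated ring carbon. Among the measured compounds shown here, no step between measured compounds covers a change of this kind, so the expectation rests on the structural change alone. The step from compound 3 to compound 4 is expected to move to a higher number in this assay, beyond the scatter: a 31-fold higher number from compound 3 to compound 4 (1.50 log units; beyond the scatter). Compound 4 is estimated at 5 nM, with a range from 0.5 nM to 50 nM.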

Compound 4, inhibition constant: 10 nM
Compound 4: middle estimate off by 2.0-fold (0.30 log units), on the low side; measured number inside the range.
By their numbers in this assay, from the lowest: compound 3; then compounds 2 and 4 (each within the scatter of the next); then compound 1.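

In this assay, among the compounds shown here, benzoyl in place of 2,4-difluorophenoxy on a saturated chain carbon gives the first single-place step (a 63-fold higher number from compound 3 to compound 4 (1.80 log units; beyond the scatter)), a large one. This position is therefore sensitive to the exchange, although compound 4 still gives 10 nM in this read-out. No evidence on the origin of the step is available.

The step does not separate the carbonyl from the loss of the two fluorines. As far as these compounds go, how an amine, a carboxylic acid or a longer chain would fare at this place remains open.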